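Another Halogen Swap on the Shared Core

The source may report more compounds than this note shows. Statements on the series, on what has been measured and on what is new or still open speak of the compounds shown alone.

Compound 2 `CN1CCN(CCCOc2cccc3nc(Nc4ccc(F)c(F)c4)ccc23)CC1` and compound 1 `CN1CCN(CCCOc2cccc3nc(Nc4ccc(Cl)c(C(F)(F)F)c4)ccc23)CC1` share a core and differ only in the ring attached to a nitrogen on an aromatic ring. In a functional assay on cells (Panel melanoma (Carcinoma cell lines), Homo sapiens) for inhibition, read by sulforhodamine B assay, with a stated time of 48 h (a lower number here means a stronger inhibitor of growth, a higher number a weaker inhibitor of growth), compound 2 gives 1690 nM and compound 1 gives 1710 nM; the two numbers sit within the scatter of each other, so neither stands apart. The step of a 1.0-fold lower number from compound 1 to compound 2 (0.01 log units; within the scatter) shows that exchanging one halogenated ring for another left this assay unchanged. Compound 3 `CN1CCN(CCCOc2cccc3nc(Nc4cc(Cl)cc(Cl)c4)ccc23)CC1` carries the change (3,5-dichlorophenyl in place of 3,4-difluorophenyl on a nitrogen on an aromatic ring). Going by the values given here, that single step is the only guide, so no shift beyond the scatter is expected, giving a 1.0-fold higher number from compound 2 to compound 3 (0.00 log units; within the scatter). Compound 3 is therefore estimated at 1700 nM, within 700 nM to 4000 nM.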

Compound 3, concentration for 50% growth inhibition: 1800 nM
Compound 3: the middle estimate sits 1.1-fold (0.02 log units) below what was measured; measured number inside the range.
By their numbers in this assay, from the lowest: compounds 2, 1 and 3 (each within the scatter of the next).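

Three differently halogenated rings on this nitrogen now give numbers within the scatter of each other in this assay (a 1.1-fold higher number from compound 2 to compound 3 (0.03 log units; within the scatter)) and (a 1.1-fold higher number from compound 1 to compound 3 (0.02 log units; within the scatter)). The 3,5-dichlorophenyl ring adds a second halogen swap at this position that leaves the reading within the scatter, so no halogenated ring among these three stands apart. Nothing available explains this outcome.

On these data alone, what a methoxy group, an amine or a carboxylic acid on this ring would do stays open. So does whether a plain phenyl ring, with no halogen at all, would read the same.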